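A few compounds are considered here, and "the series" means these few. Any claim that something is new, unique, unknown or untested is made for them only; others in the source may bear on it.

Measured compounds in an assay on HeLa cells for inhibition of Kinesin-like protein KIF15 (Homo sapiens), read by microscopy, with stated times of 2 s and 20 s, tested at 750 nM; on this read-out lower numbers stand for less inhibition and higher numbers for more inhibition at the one concentration tested (going by the name of the read-out):
- compound 1 `Cc1cc(/C=C2\C(=O)Nc3ccc(C(=O)c4ccco4)cc32)cc(C)c1O` gives 9%
- compound 2 `O=C1Nc2ccc(C(=O)c3ccco3)cc2/C1=C/c1ccc(O)nc1` gives 26.5%
- compound 3 `O=C1Nc2ccc(C(=O)c3ccco3)cc2/C1=C/c1ccnc(Cl)c1` gives 15.8%

Compound 3 is second highest of the three numbers in this assay; compound 1 lies nearest, with a number 6.8 percentage points higher from compound 1 to compound 3 (within the scatter), and compound 2 furthest, with a number 10.7 percentage points lower from compound 2 to compound 3 (beyond the scatter). The change to compound 4 `COc1ccc(/C=C2\C(=O)Nc3ccc(C(=O)c4ccco4)cc32)cc1Br` is 3-bromo-4-methoxyphenyl in place of 2-chloropyridin-4-yl on a double-bonded chain carbon bound to a double-bonded ring carbon.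

Among the compounds with values here, two measured steps bear on it. The swap of a carbon-only ring for the chloropyridyl ring, a number 6.8 percentage points higher from compound 1 to compound 3 (within the scatter), stayed within the scatter. The step of a number 17.5 percentage points higher from compound 1 to compound 2 (beyond the scatter) shows that a change at this same position can move the number, though only modestly. Compound 4 carries a carbon-only ring at the same place as compound 1, so the step in this assay is expected to be small, if anything downward, and likely within the scatter: the expected step is a number 3.8 percentage points lower from compound 3 to compound 4 (within the scatter).

Compound 4 is estimated at 12%, with a range from 2% to 26%.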

Compound 4, a percentage reported as inhibition, at one concentration (the size of the read-out at that concentration, not a potency): 2.3%
Estimate against measurement, compound 4: 9.7 percentage points above; measured number inside the range.
By their numbers in this assay, from the lowest: compounds 4, 1 and 3 (each within the scatter of the next, the first and the last beyond it); then compound 2.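

In this assay, replacing 2-chloropyridin-4-yl with 3-bromo-4-methoxyphenyl gives a number 13.5 percentage points lower from compound 3 to compound 4 (beyond the scatter), so a carbon-only ring at this place can now be separated from a pyridine ring, which the earlier step between the first carbon-only ring and the chloropyridine did not show. The change from 6-hydroxypyridin-3-yl gives a larger step, a number 24.2 percentage points lower from compound 2 to compound 4 (beyond the scatter), widening the span seen at this place. The two carbon-only rings do not separate, with a number 6.7 percentage points lower from compound 1 to compound 4 (within the scatter), although compound 1 and compound 3 also lie within the scatter of each other, so the ring type alone does not sort the series.

No measurement given here explains these differences. Going by these compounds, whether an amine in place of the hydroxyl on the pyridine ring would keep the number of compound 2 remains open.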